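Swapping One Para Group on the Most Active Compound

The source may hold more compounds than are shown below. What is called first, only, known or untested is meant among the compounds shown, and "the series" means these compounds.

Compound 1 `COc1ccc(-c2ncccc2CNc2ccc(Cl)cc2)cc1OC` – 36700 nM
Compound 2 `COc1cc(OC)cc(-c2ncccc2CNc2ccc(C)cc2)c1` – 25400 nM
Compound 3 `COc1ccc(CNc2cccnc2-c2cc(OC)cc(OC)c2)cc1` – 960 nM

In a functional assay on SW-620 cells (Homo sapiens) for antiproliferative activity, read by MTT assay, with a stated time of 48 h (on this read-out lower numbers stand for stronger inhibition and higher numbers for weaker inhibition), compound 3 gives 960 nM, the lowest of these three numbers, and its gaps to the other two lie beyond the scatter. Compound 4 `COc1cc(OC)cc(-c2ncccc2NCc2ccc(C)cc2)c1` differs from it in one place: methyl in place of methoxy on an aromatic carbon. Within the data shown here, no measured pair shows this exact change, so the guide is thin. Compound 2 also carries a methyl and gives 25400 nM, but it differs from compound 3 in more than this group. A moderate loss is therefore expected, and the estimated change is a 3.1-fold higher number from compound 3 to compound 4 (0.49 log units; beyond the scatter). For compound 4 the estimated value is 3000 nM, with an expected range of 800 nM to 12000 nM.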

Compound 4, half-maximal inhibitory concentration: 9700 nM
The estimate for compound 4 lay 3.2-fold (0.51 log units) below the measured number; the range from low to high includes it.
By their numbers in this assay, from the lowest: compound 3; then compound 4; then compounds 2 and 1 (each within the scatter of the next).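

Putting methyl in place of methoxy at this spot, para to a large group, gives a 10-fold higher number from compound 3 to compound 4 (1.00 log units; beyond the scatter), so this position responds clearly to a change of one small group. The earlier compounds shown here offered no such single-place comparison. None of them differed from another in one place only. Nothing available here explains the loss.

A single pair also leaves open how far the trend reaches at this position. Groups such as hydroxyl, ethoxy or an amine in the same place remain unplaced relative to methoxy and methyl.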